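Swapping the aryl group on the hydrazone of compound 2

The compounds below may be only part of what the source reports. "The series", "measured", "known", "first", "only" and "open" are said of these compounds alone.

Among the measured compounds shown here, compound 2 `COc1cc(/C=N/NC(=O)Nc2ccc(Oc3ccnc(-c4nncn4CCN(C)C)c3)c(F)c2)cc(OC)c1OC` stands highest of the two numbers so far in a functional assay on U-87MG ATCC cells (Homo sapiens) for cytotoxicity, read by MTT assay, with a stated time of 72 h; on this read-out lower numbers stand for stronger inhibition and higher numbers for weaker inhibition; in this assay compound 2 gives 22500 nM. Its nearest neighbour is compound 1 `CN(C)CCn1cnnc1-c1cc(Oc2ccc(NC(=O)N/N=C/c3ccc(O)c(Br)c3)cc2F)ccn1`, which in this assay gives 12400 nM, and the step of a 1.8-fold higher number from compound 1 to compound 2 (0.26 log units; within the scatter) lies within the scatter, so the two are not told apart by these data.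

Compound 3 `CN(C)CCn1cnnc1-c1cc(Oc2ccc(NC(=O)N/N=C/c3cccc(Br)c3)cc2F)ccn1` is made from compound 2 by one change: 3-bromophenyl in place of 3,4,5-trimethoxyphenyl on a carbon with a double bond to nitrogen. For the measured compounds named here, the only measured step that bears on this position is a 1.8-fold higher number from compound 1 to compound 2 (0.26 log units; within the scatter), and it did not move the number beyond the scatter. Going by the values given here, compound 3 carries a bromine on the ring, as compound 1 does, but no hydroxyl, and no measured pair isolates either feature on its own.

On this basis only a small move, if any, is expected. The expected step is a 1.5-fold lower number from compound 2 to compound 3 (0.18 log units; within the scatter), which is within the scatter. Compound 3 is therefore estimated at 15000 nM in this assay, with a range from 6000 nM to 40000 nM.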

Compound 3, half-maximal inhibitory concentration: 830 nM
Estimate against measurement, compound 3: 18-fold (1.26 log units) above; measured number outside the range, below it.
By their numbers in this assay, from the lowest: compound 3; then compounds 1 and 2 (each within the scatter of the next).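

In this assay this position proves far more sensitive than the earlier pair suggested: that pair gave only a 1.8-fold higher number from compound 1 to compound 2 (0.26 log units; within the scatter), whereas 3-bromophenyl in place of 3,4,5-trimethoxyphenyl gives a 27-fold lower number from compound 2 to compound 3 (1.43 log units; beyond the scatter). Among the compounds shown here, the second new step separates a feature that the earlier compounds left tied to the bromine: both compounds carry the bromine, and hydrogen in place of hydroxy on an aromatic carbon gives a 15-fold lower number from compound 1 to compound 3 (1.17 log units; beyond the scatter). A single hydroxy group on this ring therefore goes with a large change in the number, and compound 1 and compound 2, though not told apart from each other, both stand well above compound 3 in this assay; no measurement at hand offers an explanation for either step.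

The part played by the bromine itself remains open, as the compounds shown do not say whether a plain phenyl, a chlorine or a single methoxy group on the ring would keep the number of compound 3. Also open, on these data alone, is whether an amine or a carboxylic acid on this ring would track the hydroxy group, and whether the same step would hold if the dimethylaminoethyl chain of the shared core were replaced by a longer chain.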